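Swapping a thioether for a fluorophenoxy group

The compounds below may be only part of what the source reports. "The series", "measured", "known", "first", "only" and "open" are said of these compounds alone.

Compounds measured so far:
Compound 1, `Nc1cc(N)c2nc(-c3ccccc3)c(NCc3ccc(F)cc3)nc2c1`: 60300 nM
Compound 2, `COc1ccc(Sc2nc3cc(N)cc(N)c3nc2-c2ccccc2)cc1`: < 100000 nM

In a functional assay on OVCAR-4 cells (Homo sapiens) for inhibition, read by sulforhodamine B assay, with a stated time of 48 h (a lower number here means that less compound is tolerated, a higher number that more compound is tolerated), compound 1 gives 60300 nM. Compound 2 is known only as a limit of the assay, < 100000 nM, which is the limit of < 100000 nM in this assay, at which 1 of the 2 values shown sits. Among the measured compounds shown here, the only measured step, a step that the limit leaves unreadable from compound 1 to compound 2, therefore gives no readable size. Compound 3 is `Nc1cc(N)c2nc(-c3ccccc3)c(Oc3ccc(F)cc3)nc2c1`, and it differs from compound 2 in one place: 4-fluorophenoxy in place of (4-methoxyphenyl)sulfanyl on an aromatic carbon. For the measured compounds named here, no measured step bears directly on this change, so no direction can be read from the numbers; the nearest point of reference is compound 1 with its 60300 nM, which carries a similar fluorinated ring on the same position of the shared core. Compound 3 is therefore expected near that value, estimated at 50000 nM (range 15000 nM to 100000 nM). The expected step is a step that the limit leaves unreadable from compound 2 to compound 3, which a limit cannot confirm.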

Compound 3, concentration lethal to 50% of the cells: < 100000 nM
Compound 3 was reported as a limit; the forecaster's own chance of this, stated with the estimate: 30%; the middle value lies beyond the limit too.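

Among the compounds shown here, compound 3 is known only as a limit of the assay, like compound 2, so no step to compound 3 from compound 2 or compound 1 can be read: the limit of < 100000 nM in this assay, at which 2 of the 3 values shown sit.
From the compounds shown here alone, whether 4-fluorophenoxy and (4-methoxyphenyl)sulfanyl truly differ in this assay stays open.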